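Chlorophenoxy in place of the dimethylcarbamoyl chain: compound 4

The compounds below may be only part of what the source reports. "The series", "measured", "known", "first", "only" and "open" are said of these compounds alone.

Compound 1 `CC(C)C[C@H](N)c1cc(C(F)(F)F)ccc1N1CCN(C(=O)CCNC2CCCCC2)CC1`: 4800 nM
Compound 2 `CC(C)C[C@H](N)c1cc(C(F)(F)F)ccc1N1CCN(C(=O)COc2ccc(Cl)cc2)CC1`: 2900 nM
Compound 3 `CC(C)C[C@H](N)c1cc(C(F)(F)F)ccc1N1CCN(C(=O)CCC(=O)N(C)C)CC1`: > 10000 nM

In an assay on HEK293 cells for displacement of a labelled ligand from Melanocortin receptor 4 (Homo sapiens) (on this read-out higher numbers stand for weaker inhibition and lower numbers for stronger inhibition), compound 1 gives 4800 nM and compound 2 gives 2900 nM. Compound 3 reaches only a limit of this assay, > 10000 nM. Compound 3 is thus the weakest of the three, sitting at the limit of > 10000 nM in this assay, at which 1 of the 3 values shown sits, so only a range is known for it.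

Compound 4 `CC(C)C[C@H](N)c1cc(C(F)(F)F)ccc1N1CCN(C(=O)COc2cccc(Cl)c2)CC1` differs from compound 3 in one place: 3-chlorophenoxy in place of (dimethylcarbamoyl)methyl on a saturated chain carbon bound to a carbonyl carbon. For the measured compounds named here, the steps that bear on this are an at least 3.4-fold higher number from compound 2 to compound 3 (0.53 log units; beyond the scatter) and an at least 2.0-fold higher number from compound 1 to compound 3 (0.31 log units; beyond the scatter), both moving away from the chain amide toward weaker binding; the 4-chlorophenoxy analogue compound 2 is the nearest measured relative of compound 4. Close to compound 2, compound 4 is therefore expected to land, giving an at least 3.3-fold lower number from compound 3 to compound 4 (0.52 log units; beyond the scatter), with an estimate of 3000 nM and a range from 1200 nM to 8000 nM.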

Compound 4, inhibition constant: 2600 nM
For compound 4 the middle estimate is 1.2-fold (0.06 log units) above the measured one; measured number inside the range.
By their numbers in this assay, from the lowest: compounds 4, 2 and 1 (each within the scatter of the next). At a limit, above all of these: compound 3.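

In this assay, shifting the chlorine on the phenoxy group changes nothing that can be resolved, with a 1.1-fold lower number from compound 2 to compound 4 (0.05 log units; within the scatter), and a 1.8-fold lower number from compound 1 to compound 4 (0.27 log units; within the scatter) likewise separates 3-chlorophenoxy from the cyclohexylamino chain by no more than the scatter. Putting 3-chlorophenoxy in place of (dimethylcarbamoyl)methyl gives an at least 3.8-fold lower number from compound 3 to compound 4 (0.58 log units; beyond the scatter). The value of compound 3 is a limit, so that step has only a lower bound: the limit of > 10000 nM in this assay, at which 1 of the 4 values shown sits.

On these data alone, whether an unsubstituted phenoxy group, a carboxylic acid or a longer chain at this place would move binding beyond the scatter stays open. As far as these compounds go, the full size of the step from compound 3 also stays open.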